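The compounds below may be only part of what the source reports. "The series", "measured", "known", "first", "only" and "open" are said of these compounds alone.

Compound 3, `Nc1scc(-c2ccccc2)c1C(=O)c1ccc(Cl)cc1`, stands highest of the three compounds measured in a functional assay on CHO cells for agonist activity at adenosine receptor A1 (Homo sapiens), read by fluorescence and ERK phosphorylation, with stated times of 30 min and 1.5 h, tested at 10 uM (on this read-out lower numbers stand for a weaker effect and higher numbers for a stronger effect at the one concentration tested), where compound 3 gives 64%. Compound 1, `Nc1scc(-c2ccccc2)c1C(=O)c1ccccc1`, gives 48% in this assay, and compound 2, `Nc1scc(-c2ccc([N+](=O)[O-])cc2)c1C(=O)c1ccccc1`, gives 47%. Two steps lead away from compound 1: a number 1 percentage points lower from compound 1 to compound 2 (within the scatter), and a number 16 percentage points higher from compound 1 to compound 3 (beyond the scatter).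

Compound 4, `Nc1scc(-c2cccc(Cl)c2)c1C(=O)c1ccc(Cl)cc1`, is reached from compound 3 by a change described as chloro in place of hydrogen on an aromatic carbon. For the measured compounds named here, two measured steps bear on this change. The step from compound 1 to compound 3 is the same kind of change, chloro in place of hydrogen on an aromatic carbon, and it read a number 16 percentage points higher from compound 1 to compound 3 (beyond the scatter). The step from compound 1 to compound 2, nitro in place of hydrogen on an aromatic carbon, read a number 1 percentage points lower from compound 1 to compound 2 (within the scatter), a change that stayed within the scatter. One chloro has already raised the read-out modestly, while the only other substitution on an aromatic carbon did nothing beyond the scatter, so the second chloro is expected to add little, if anything.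

The step from compound 3 to compound 4 is therefore estimated as a number 4 percentage points higher from compound 3 to compound 4 (within the scatter). Compound 4 is expected to give 68% in this assay, with a range from 55% to 80%.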

Compound 4, a percentage reported as activity, at one concentration (the size of the read-out at that concentration, not a potency): 75%
Beside the measured number, compound 4's estimate is 7 percentage points below it; the measured number falls inside the stated range.
By their numbers in this assay, from the lowest: compounds 2 and 1 (each within the scatter of the next); then compound 3; then compound 4.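

The step to the 3-chlorophenyl compound, a number 11 percentage points higher from compound 3 to compound 4 (beyond the scatter) in this assay, shows that the phenyl to 3-chlorophenyl change, made on an aromatic carbon meta to a large group, moves the read-out beyond the scatter even when a chloro is already present elsewhere in the molecule. For the compounds shown here, the earlier chloro step, a number 16 percentage points higher from compound 1 to compound 3 (beyond the scatter), was made on the other aromatic ring, and the only earlier change on this phenyl, a number 1 percentage points lower from compound 1 to compound 2 (within the scatter), stayed within the scatter, so this is the first sign that substitution on this phenyl can raise the read-out and that two chloro groups together can stand above one. No measurement shown here offers an explanation for this rise.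

The compounds shown leave open whether the 3-chlorophenyl change would give a similar step on compound 1, which lacks the first chloro, and whether a chloro placed elsewhere on this phenyl would do the same. They also leave open what a methoxy group, an amine or a carboxylic acid would do at this place, and, with a single tested concentration, how the compounds rank in potency.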